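This account rests on a few compounds, and the source may have more. Where it says the series, first, only, none or still open, it means among the compounds named here.

Measured so far:
compound 1, `Clc1cccc(-c2cc(-c3ccc(Cl)o3)cc(-c3cccs3)n2)c1`: 18100 nM
compound 2, `Clc1ccc(-c2cc(-c3ccco3)cc(-c3cccs3)n2)cc1`: > 100000 nM

Compound 1 is `Clc1cccc(-c2cc(-c3ccc(Cl)o3)cc(-c3cccs3)n2)c1`. In a functional assay on DU-145 cells (Homo sapiens) for cytotoxicity, in the presence of a further agent that is not named here (on this read-out higher numbers stand for weaker inhibition and lower numbers for stronger inhibition), compound 1 gives 18100 nM. Compound 2 is `Clc1ccc(-c2cc(-c3ccco3)cc(-c3cccs3)n2)cc1`. In this assay compound 2 returns only > 100000 nM, which is a limit of the assay and not a number. Compound 2 therefore stands at the limit of > 100000 nM in this assay, at which 1 of the 2 values shown sits, with no number that can be set against compound 1. The two structures differ in two places, so their values show no more than that compound 1 has a number and compound 2 does not.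

Compound 3 is `Clc1ccc(-c2cc(-c3ccc(Cl)o3)cc(-c3cccs3)n2)cc1`, not yet measured. From compound 2 it differs by chloro in place of hydrogen on an aromatic carbon. Among the compounds with values here, no measured step of this kind is available. A number rather than a limit is expected for compound 3 because compound 1 with the same 5-chlorofuran-2-yl group gives 18100 nM. In this assay compound 3 is estimated at 40000 nM, within 12000 nM to 150000 nM. The expected change amounts to an at least 2.5-fold lower number from compound 2 to compound 3 (0.39 log units; beyond the scatter).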

Compound 3, half-maximal inhibitory concentration: 19200 nM
Beside the measured number, compound 3's estimate is 2.1-fold (0.32 log units) above it; the range from low to high includes it.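

In this assay, within the data shown here, the change from furan-2-yl to 5-chlorofuran-2-yl, with chloro in place of hydrogen on the ring carbon next to the ring oxygen, gives an at least 5.2-fold lower number from compound 2 to compound 3 (0.71 log units; beyond the scatter); this is the only single-place step at this position, and it is beyond the scatter. The value of compound 2 is a limit of the assay and not a number: the limit of > 100000 nM in this assay, at which 1 of the 3 values shown sits. With 5-chlorofuran-2-yl held fixed, 4-chlorophenyl in place of 3-chlorophenyl gives a 1.1-fold higher number from compound 1 to compound 3 (0.03 log units; within the scatter), which is within the scatter, so this pair does not separate the two chlorophenyl groups.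

The compounds shown do not tell whether the step from compound 2 to compound 3 is particular to chloro, since no other group, such as a methyl, a bromo or an amine, appears on that furan carbon. They also leave open whether the pair of chlorophenyl groups would stay within the scatter with an unsubstituted furan-2-yl, and how far a change at the thiophene or the phenyl ring, such as a carboxylic acid on the phenyl ring, would move the number in this assay.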